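Swapping the Distal Aromatic Ring of Compound 1

The source may report more compounds than this note shows. Statements on the series, on what has been measured and on what is new or still open speak of the compounds shown alone.

Compound 1 `O=C1C(=O)N(Cc2ccc(-c3cncnc3)cc2)c2ccc(OC(F)(F)F)cc21` is the starting point. In a functional assay on CHO cells for positive allosteric modulation of muscarinic acetylcholine receptor M5 (Homo sapiens), read by FLIPR and calcium flux, with a stated time of 1 h (a lower number here means that less compound is needed, a higher number that more compound is needed for the effect), compound 1 gives 2100 nM, the lowest of the two numbers recorded here. Its nearest neighbour is compound 3 `O=C1C(=O)N(Cc2ccc(Br)cc2)c2ccccc21`, which gives 4600 nM in this assay, a gap that lies beyond the usual scatter of repeats. Compound 2 `O=C1C(=O)N(Cc2ccc(-c3ccncc3)cn2)c2ccc(OC(F)(F)F)cc21` reaches only a limit of the test, > 30000 nM in this assay; this value is the limit of > 30000 nM in this assay, at which 1 of the 3 values shown sits. Compound 4 `O=C1C(=O)N(Cc2ccc(Oc3cccc(F)n3)cc2)c2ccc(OC(F)(F)F)cc21` has not yet been measured; it differs from compound 1 by (6-fluoropyridin-2-yl)oxy in place of pyrimidin-5-yl on an aromatic carbon. Among the compounds with values here, no measured pair in this set makes a change of this kind, so the direction is open, and a step of only modest size, within or just beyond the scatter, is expected: a 1.2-fold lower number from compound 1 to compound 4 (0.07 log units; within the scatter). Compound 4 is therefore estimated at 1800 nM, between 500 nM and 7000 nM.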

Compound 4, half-maximal effective concentration: 1500 nM
Estimate against measurement, compound 4: 1.2-fold (0.08 log units) above; the range from low to high includes it.
By their numbers in this assay, from the lowest: compounds 4 and 1 (each within the scatter of the next); then compound 3. At a limit, above all of these: compound 2.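

Replacing pyrimidin-5-yl with (6-fluoropyridin-2-yl)oxy, para to a large group, gives a 1.4-fold lower number from compound 1 to compound 4 (0.15 log units; within the scatter) in this assay and so leaves the two compounds indistinguishable. Within the data shown here, this is the first pair here that differs in one place, and it shows that this aromatic carbon can carry a larger group, joined through oxygen and bearing fluorine, while the effect remains. Nothing measured here explains this match.

Still open, as far as these compounds go, is whether the fluorine or the oxygen link matters on its own. Also open, from the compounds shown here alone, is what an amine or a carboxylic acid would do at this position.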